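Benzyl in place of 3-aminopropyl on the amine of compound 1

The compounds below may be only part of what the source reports. "The series", "measured", "known", "first", "only" and "open" are said of these compounds alone.

compound 1 `NCCCNc1c(C(=O)NCc2ccc(F)cc2)nc(Br)c2cccnc12`: > 20000 nM
compound 2 `N[C@H]1CC[C@H](Nc2c(C(=O)NCc3ccc(Oc4ccccc4)cc3)nc(Br)c3cccnc23)CC1`: "not determined" (no result reported)
compound 3 `COc1ccc(CNC(=O)c2nc(Br)c3cccnc3c2N[C@H]2CC[C@H](N)CC2)cc1`: 3000 nM

Three compounds share the core of compound 1 and were tested in a functional assay on HCT-116 cells (Homo sapiens) for cytotoxicity, read by MTT assay, with a stated time of 72 h; on this read-out lower numbers stand for stronger inhibition and higher numbers for weaker inhibition. Compound 1 gives only a limit, > 20000 nM, not a number. Compound 1 thus stands at the limit of > 20000 nM in this assay, at which 1 of the 3 values shown sits, so its true position is open. Compound 2 has no result in this assay. Compound 3 gives 3000 nM in this assay. Among the compounds with values here, no two measured compounds differ in one place, so no measured step can be read. Compound 4 `O=C(NCc1ccc(F)cc1)c1nc(Br)c2cccnc2c1NCc1ccccc1` is not yet measured; it differs from compound 1 by phenyl in place of 2-aminoethyl on a saturated chain carbon bound to a nitrogen on an aromatic ring. With only a limit as the starting point, compound 4 is expected to stay close to it, giving an estimated 15000 nM with a range from 4000 nM to 60000 nM, which is an expected step of an at least 1.3-fold lower number from compound 1 to compound 4 (0.12 log units; that floor lies within the scatter).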

Compound 4, half-maximal inhibitory concentration: > 20000 nM
Compound 4 gave a limit, no number (the forecaster's own chance of this, stated with the estimate: 55%); middle value at least 1.3-fold (0.12 log units) away from the limit.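

In this assay, within the data shown here, compound 1 and compound 4 both give only a limit, so no step between them can be read: the limit of > 20000 nM in this assay, at which 2 of the 4 values shown sit. Left open is whether benzyl in place of 3-aminopropyl changes the read-out at all.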